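Sulfonyl and carbamate variants at the chain carbon of the core

The compounds below may be only part of what the source reports. "The series", "measured", "known", "first", "only" and "open" are said of these compounds alone.

Measured so far:
- compound 1 `CCCCc1ccc(CN(Cc2ccccc2)S(C)(=O)=O)c(=O)n1Cc1ccc(-c2ccccc2-c2nn[nH]n2)cc1`: 2 nM
- compound 2 `CCCCc1ccc(C)c(=O)n1Cc1ccc(-c2ccccc2-c2nn[nH]n2)cc1`: 7 nM
- compound 3 `CCCCc1ccc(CNC(=O)OC(C)(C)C)c(=O)n1Cc1ccc(-c2ccccc2-c2nn[nH]n2)cc1`: 10 nM

In a functional assay (aorta) for antagonist activity, with Oryctolagus cuniculus as the target (a higher number here means a weaker inhibitor, a lower number a stronger inhibitor), compound 3 gives 10 nM, the highest number of the three measured. Its nearest neighbour is compound 2, which gives 7 nM; the two lie within the scatter of one another. Compound 1 gives 2 nM, and the step of a 5.0-fold higher number from compound 1 to compound 3 (0.70 log units; beyond the scatter) lies beyond the scatter, so compound 3 is clearly the weaker of that pair in this assay.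

Compound 4 `CCCCc1ccc(CNS(=O)(=O)c2ccccc2)c(=O)n1Cc1ccc(-c2ccccc2-c2nn[nH]n2)cc1` has not yet been measured. It differs from compound 3 in one place: phenylsulfonyl in place of tert-butoxycarbonyl on an amine nitrogen.

For the measured compounds named here, two measured steps bear on this change. The step of a 1.4-fold higher number from compound 2 to compound 3 (0.15 log units; within the scatter) shows that adding the carbamate-bearing group at the chain carbon changes little. The step of a 5.0-fold higher number from compound 1 to compound 3 (0.70 log units; beyond the scatter) shows that the substituted sulfonamide of compound 1 gives a modestly stronger inhibitor than the carbamate of compound 3. Compound 4 carries a sulfonyl group on the same amine nitrogen, with an aromatic ring entering, so a return part of the way toward compound 1 is expected, though compound 4 lacks the benzyl of compound 1 and the nitrogen keeps a hydrogen.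

For compound 4 a modest step to a lower number is expected, a 2.0-fold lower number from compound 3 to compound 4 (0.30 log units; within the scatter). The estimate for compound 4 in this assay is 5 nM, with a range from 1.5 nM to 15 nM.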

Compound 4, half-maximal inhibitory concentration: 7 nM
Compound 4: the middle estimate sits 1.4-fold (0.15 log units) below what was measured; low and high end bracket the measured number.
By their numbers in this assay, from the lowest: compound 1; then compounds 2, 4 and 3 (each within the scatter of the next).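

In this assay, phenylsulfonyl and tert-butoxycarbonyl on the amine nitrogen cannot be told apart (a 1.4-fold lower number from compound 3 to compound 4 (0.15 log units; within the scatter)), although an aromatic ring enters with the phenylsulfonyl group. The (phenylsulfonyl)amino group on the saturated chain carbon also cannot be told apart from hydrogen (no change at the digits printed from compound 2 to compound 4 (within the scatter)), so a sulfonyl group on this nitrogen is not enough on its own to give the lower number of compound 1. The gap to that compound remains beyond the scatter (a 3.5-fold higher number from compound 1 to compound 4 (0.54 log units; beyond the scatter)), and this single step replaces the whole benzyl(methylsulfonyl)amino group, changing the group on sulfur and the benzyl on nitrogen together; no measurement in hand accounts for the gap.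

The compounds shown leave open how much of that gap belongs to the benzyl on nitrogen and how much to the methyl on sulfur, a question that (methylsulfonyl)amino and benzyl(phenylsulfonyl)amino at this chain carbon would separate. They also leave open whether a free amine or a carboxylic acid at this position would stay within the scatter of compounds 2, 3 and 4.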